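Removing a Halogen From a Weakly Cytotoxic Compound

This account rests on a few compounds, and the source may have more. Where it says the series, first, only, none or still open, it means among the compounds named here.

So far, three compounds have been tested in a functional assay on HeLa cells (Homo sapiens) for cytotoxicity, read by MTT assay, with a stated time of 24 h; on this read-out lower numbers stand for stronger inhibition and higher numbers for weaker inhibition. Compound 1 `O=c1nc2ccc(Cl)cn2cc1Cc1ccc(F)cc1C(F)(F)F` reaches only a limit of this assay, > 1000000 nM. Compound 2 `Nc1cc(Br)cn2cc(Cc3ccccc3)c(=O)nc12` also stops at a limit, > 1000000 nM. Compound 3 `Nc1cccn2cc(Cc3ccccc3)c(=O)nc12` gives a measurable number, 112000 nM. So compound 1 stands at the edge of what this assay can report, together with one other compound (the limit of > 1000000 nM in this assay, at which 2 of the 3 values shown sit).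

Compound 4 `O=c1nc2ccccn2cc1Cc1ccc(F)cc1C(F)(F)F` differs from compound 1 by hydrogen in place of chloro on an aromatic carbon. Within the data shown here, the only measured step, an at least 8.9-fold lower number from compound 2 to compound 3 (0.95 log units; beyond the scatter), also removes a halogen from an aromatic carbon and pulls the number down out of the limit. A step of similar direction, though uncertain in size, is therefore expected here: compound 4 is expected to show an at least 4.0-fold lower number from compound 1 to compound 4 (0.60 log units; beyond the scatter). The estimate for compound 4 is 250000 nM, with a range from 60000 nM to 1000000 nM.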

Compound 4, half-maximal inhibitory concentration: 88000 nM
The estimate for compound 4 lay 2.8-fold (0.45 log units) above the measured number; measured number inside the range.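

Hydrogen in place of chloro on this aromatic carbon gives an at least 11-fold lower number from compound 1 to compound 4 (1.05 log units; beyond the scatter) in this assay, so the drop seen on removing bromo also appears with a different halogen and a differently substituted compound. Neither of the two halogen-to-hydrogen pairs goes against this. From the compounds shown here alone, the full size of the step stays unknown, because compound 1 gives only a limit: the limit of > 1000000 nM in this assay, at which 2 of the 4 values shown sit.

Going by these compounds, whether a methyl group, an amine or a nitrile on this carbon would also give a measurable number remains open. So does whether the halogen itself or merely any group larger than hydrogen matters here.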